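The source may report more compounds than this note shows. Statements on the series, on what has been measured and on what is new or still open speak of the compounds shown alone.

Working notes on the series. Among the compounds with values here, in a functional assay on SK-BR-3 cells (Homo sapiens) for cytotoxicity, read by MTT assay, with a stated time of 72 h (on this read-out higher numbers stand for weaker inhibition and lower numbers for stronger inhibition), compound 1 `N[C@H]1CC[C@H](Nc2c(C(=O)NCc3ccco3)nc(Br)c3cccnc23)CC1` gives 10000 nM, the only number so far. On these data alone, compound 2 `CN(C)c1ccc(CNC(=O)c2nc(Br)c3cccnc3c2N[C@H]2CC[C@H](N)CC2)cc1` has no number to place against it: its result stands as "not determined" (no result reported), so its position in this assay is unknown. Compound 3 `C[C@H](NC(=O)c1nc(Br)c2cccnc2c1N[C@H]1CC[C@H](N)CC1)c1ccc(F)cc1` shares the core of compound 2 and carries 1-(4-fluorophenyl)ethyl in place of 4-(dimethylamino)benzyl on an amide-type nitrogen. Both groups hold one six-membered aromatic ring of carbon only, and the change adds 1 defined stereocentre. No step beyond the scatter is expected from this change in this assay, though with no number for compound 2 this cannot be checked and no direction can be assigned. Within the data shown here, the only anchor is compound 1 at 10000 nM, so the expectation is a weak result, somewhat stronger than that anchor. For compound 3 the expected value is 4000 nM, with an estimated range of 800 nM to 15000 nM.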

Compound 3, half-maximal inhibitory concentration: 9000 nM
The estimate for compound 3 lay 2.3-fold (0.35 log units) below the measured number; measured number inside the range.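

In this assay, within the data shown here, 1-(4-fluorophenyl)ethyl in place of (furan-2-yl)methyl on the amide-type nitrogen gives a 1.1-fold lower number from compound 1 to compound 3 (0.05 log units; within the scatter), the first step that can be read at this position. On the shared core, these two groups therefore cannot be told apart in this read-out. The step from 4-(dimethylamino)benzyl to 1-(4-fluorophenyl)ethyl cannot be read, as compound 2 has no number, and no evidence on hand bears on this result.

The compounds shown leave open whether a group of another kind on this amide-type nitrogen, such as an aminoethyl chain or a carboxylic acid on a longer chain, would give a step beyond the scatter. Also open, on these data alone, is how the opposite configuration of the 1-(4-fluorophenyl)ethyl stereocentre would read.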